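The compounds below may be only part of what the source reports. "The series", "measured", "known", "first", "only" and "open" are said of these compounds alone.

Measured compounds:
compound 1, `CC(C)CCCCCCCCCCCCC(=O)NCC(=O)N[C@@H]1[C@@H](O)[C@H](O)[C@@H](Nc2ncnc3[nH]cnc23)O[C@H]1C` — 1.1 uM
compound 2, `CCCCCCCCCCCC(=O)NCC(=O)N[C@@H]1[C@@H](O)[C@H](O)[C@@H](Nc2ncnc3[nH]cnc23)O[C@H]1CO` — 5.5 uM
compound 3, `CCCCCCCCCCCCCCCCC(NC(C)=O)C(=O)N[C@@H]1[C@@H](O)[C@H](O)[C@@H](Nc2ncnc3[nH]cnc23)O[C@H]1C` — > 1000 uM (a limit)

In a functional assay on L1210 cells (Mus musculus) for inhibition, with a stated time of 3 h (on this read-out lower numbers stand for an effect already at smaller amounts and higher numbers for an effect only at larger amounts of compound), compound 1 gives 1.1 uM, the lowest of the two numbers obtained. Compound 2, which carries a shorter acyl chain and a hydroxymethyl on the shared core, gives 5.5 uM in this assay, a number beyond the usual scatter above compound 1. For compound 3 this assay reports only a limit, > 1000 uM, at which one of the three values sits (the limit of > 1000 uM in this assay, at which 1 of the 3 values shown sits).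

The next compound, compound 4, `CCCCCC(=O)NCC(=O)N[C@@H]1[C@@H](O)[C@H](O)[C@@H](Nc2ncnc3[nH]cnc23)O[C@H]1C`, differs from compound 1 by hydrogen in place of 8-methylnonyl on a saturated chain carbon, five bonds along the chain from a carbonyl carbon. No step between measured compounds isolates such a shortening of the chain, so the expectation rests on the whole of what is shown: the only other number, compound 2 with 5.5 uM, belongs to a compound with a shorter chain than compound 1 and lies above it. For compound 3 only a limit is known. Cutting the chain of compound 1 so far back is therefore expected to raise the number markedly, by a step of a 91-fold higher number from compound 1 to compound 4 (1.96 log units; beyond the scatter). Compound 4 is estimated at 100 uM in this assay, within a range from 15 uM to 800 uM.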

Compound 4, concentration for half-maximal effect: > 1000 uM
Compound 4: only a limit was reported; the forecaster's own chance of this, stated with the estimate: 20%; middle value at least 10-fold (1.00 log units) from the limit.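

In this assay, putting hydrogen in place of 8-methylnonyl on a saturated chain carbon, five bonds along the chain from a carbonyl carbon, gives an at least 900-fold higher number from compound 1 to compound 4 (2.95 log units; beyond the scatter). Among these compounds, this is the first step that can be read between two of the compounds, and it shows that this one change is enough to carry the number from compound 1 up to a limit. The value of compound 4 is a limit, so the full size of the step stays unknown: the limit of > 1000 uM in this assay, at which 2 of the 4 values shown sit.

The compounds shown leave open at which chain length between those of compound 4 and compound 1 the number begins to fall, and whether an unbranched chain of the length found in compound 1 would behave alike. Also open, from the compounds shown here alone, is whether a shortened chain carrying an amine or a carboxylic acid would give a measurable number.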